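The source may hold more compounds than are shown below. What is called first, only, known or untested is meant among the compounds shown, and "the series" means these compounds.

Measured so far:
compound 1, `CCCn1c(=O)c2nc(C(C)N)[nH]c2n(CCC)c1=O`, gives 3000 nM in an assay on cell membranes for binding affinity to adenosine receptor A1 (Cavia porcellus); on this read-out lower numbers stand for stronger inhibition and higher numbers for weaker inhibition
compound 2, `CCCn1c(=O)c2nc(C(CC)CC)[nH]c2n(CCC)c1=O`, gives 19 nM in this assay

Compound 2 holds the lowest of the two numbers. For the measured compounds named here, the only measured step is a 160-fold lower number from compound 1 to compound 2 (2.20 log units; beyond the scatter), a swap of an amine-bearing group for a plain chain. Compound 3, `CCCC(CCC)c1nc2c(=O)n(CCC)c(=O)n(CCC)c2[nH]1`, differs from compound 2 by 1-propylbutyl in place of pentan-3-yl on an aromatic carbon. Going by the values given here, no measured step exchanges one plain chain for another, so that large step gives little direct guidance here. Compound 3 is therefore expected to stay close to compound 2, with a step of a 1.3-fold lower number from compound 2 to compound 3 (0.10 log units; within the scatter) and an estimated value of 15 nM, in a range from 5 nM to 60 nM.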

Compound 3, inhibition constant: 78 nM
The estimate for compound 3 lay 5.2-fold (0.72 log units) below the measured number; measured number outside the range, above it.
By their numbers in this assay, from the lowest: compound 2; then compound 3; then compound 1.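

At this position on an aromatic carbon, plain chains are not interchangeable: in this assay 1-propylbutyl in place of pentan-3-yl gives a 4.1-fold higher number from compound 2 to compound 3 (0.61 log units; beyond the scatter) and so a real loss, although neither group carries a hydrogen-bond donor or acceptor. The longer chain still keeps much of the advantage over 1-aminoethyl, with a 38-fold lower number from compound 1 to compound 3 (1.59 log units; beyond the scatter) on that change. Nothing measured here explains the loss.

The compounds shown leave open whether a smaller chain such as isopropyl, or a ring such as cyclopentyl, would match pentan-3-yl. They also leave open whether the high number of compound 1 follows from its amine or from its shorter chain.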